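The compounds below may be only part of what the source reports. "The series", "measured", "known", "first", "only" and "open" are said of these compounds alone.

For the measured compounds named here, in a functional assay on KB cells (Homo sapiens) for cytotoxicity, read by MTT assay, with a stated time of 72 h (on this read-out higher numbers stand for weaker inhibition and lower numbers for stronger inhibition), compound 3 `O=S(=O)(c1ccccc1)c1nc2ccccc2nc1N1CCCC(O)C1` gives 3590 nM, the lowest number measured so far. Compound 2 `Cc1ccc(S(=O)(=O)c2nc3ccccc3nc2N2CCc3ccccc3C2)cc1` gives a higher number, 32100 nM. For compound 1 `Cc1ccc(S(=O)(=O)c2nc3ccccc3nc2N2CCCC2)cc1`, the reading of > 50000 nM is a limit of the assay and not a number.

Compound 4 `Cc1ccc(S(=O)(=O)c2nc3ccccc3nc2N2CCCC(O)C2)cc1` differs from compound 3 in one place: methyl in place of hydrogen on an aromatic carbon, para to a large group (methyl in place of hydrogen on an aromatic carbon). Going by the values given here, the only measured step, an at least 1.5-fold lower number from compound 1 to compound 2 (0.19 log units; that floor lies within the scatter), concerns a different group, so no measurement isolates this change. No shift beyond the scatter is therefore expected, and the estimated step is a 1.3-fold higher number from compound 3 to compound 4 (0.10 log units; within the scatter). The expected value for compound 4 is 4500 nM, with an estimated range from 1500 nM to 15000 nM.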

Compound 4, half-maximal inhibitory concentration: 6080 nM
Beside the measured number, compound 4's estimate is 1.4-fold (0.13 log units) below it; low and high end bracket the measured number.
By their numbers in this assay, from the lowest: compounds 3 and 4 (each within the scatter of the next); then compound 2. At a limit, above all of these: compound 1.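

In this assay the change from phenyl to 4-methylphenyl gives a 1.7-fold higher number from compound 3 to compound 4 (0.23 log units; within the scatter) and so stays within the scatter. With 4-methylphenyl kept, 3-hydroxypiperidin-1-yl gives a 5.3-fold lower number from compound 2 to compound 4 (0.72 log units; beyond the scatter) against 1,2,3,4-tetrahydroisoquinolin-2-yl and an at least 8.2-fold lower number from compound 1 to compound 4 (0.91 log units; beyond the scatter) against pyrrolidin-1-yl, so the nitrogen-linked ring moves the number beyond the scatter while this methyl does not. The step from compound 1 is only a floor, set by a limit and not by a number: the limit of > 50000 nM in this assay, at which 1 of the 4 values shown sits.

Still open, going by these compounds, is whether methoxy, a chlorine atom or a carboxylic acid in place of this methyl would shift the number. Also open, on these data alone, is what the hydroxyl of 3-hydroxypiperidin-1-yl contributes on its own.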